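From an Inactive Acid to a Biphenyl Ester

This account rests on a few compounds, and the source may have more. Where it says the series, first, only, none or still open, it means among the compounds named here.

Compound 1 `Cc1ccccc1-n1nc(C)c2c1NC(=O)[C@H](C)S[C@@H]2c1ccc(Oc2ccccc2C(=O)O)cc1` was tested in an assay on isolated protein for agonist activity at Bile acid receptor (Homo sapiens), read by AlphaScreen, with a stated time of 30 min (on this read-out higher numbers stand for an effect only at larger amounts of compound and lower numbers for an effect already at smaller amounts), where compound 1 came out as "not active" (no number reported), so no number stands for it. Two related compounds set the scale: compound 2 `Cc1nn(-c2ccccc2I)c2c1C(c1ccc(Oc3ccccc3)cc1)SC(C)C(=O)N2` gives 1300 nM in this assay, and compound 3 `COc1cc([C@H]2S[C@@H](C)C(=O)Nc3c2c(C)nn3-c2ccccc2C)ccc1Oc1ccccc1` gives 1900 nM in this assay; these two values lie within the scatter of each other. Compound 4 `COC(=O)c1ccc(-c2ccc([C@H]3S[C@@H](C)C(=O)Nc4c3c(C)nn4-c3ccccc3C)cc2)cc1` has not been measured. It differs from compound 1 in one place: 4-(methoxycarbonyl)phenyl in place of 2-carboxyphenoxy on an aromatic carbon. Among the measured compounds shown here, no measured pair shows how large such a step is, and compound 1 offers no number to start from, so neither size nor direction can be computed; the expectation is simply that compound 4 lands in the micromolar region occupied by compounds 2 and 3. Compound 4 is therefore expected at 2000 nM, with a range from 500 nM to 10000 nM.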

Compound 4, half-maximal effective concentration: "not active" (no number reported)
Compound 4: no number reported; there is nothing to compare the estimate with.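

Compound 1 and compound 4 both came out without a number, and no step can be read between them. Nothing shown bears on this result. The compounds shown leave open how far 4-(methoxycarbonyl)phenyl in place of 2-carboxyphenoxy changes activity.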